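Series notes: microsomal half-life, estimate for compound 4

This account rests on a few compounds, and the source may have more. Where it says the series, first, only, none or still open, it means among the compounds named here.

Three compounds have been run in an ADME assay on microsomes from liver (Homo sapiens) for metabolic stability, read by LC-MS, using NADPH, tested at 5 uM; on this read-out lower numbers stand for a shorter-lived compound and higher numbers for a longer-lived compound:
- Compound 1 `NS(=O)(=O)c1cc(-c2nnc(CCl)o2)c(Cl)cc1SCc1ccccc1` gives 0.235 h
- Compound 2 `NC(=O)c1cn(Cc2nnc(-c3cc(S(N)(=O)=O)c(SCc4ccccc4)cc3Cl)o2)nn1` gives 0.435 h
- Compound 3 `NS(=O)(=O)c1cc(-c2nnc(CNC(=O)c3ccccc3)o2)c(Cl)cc1SCc1ccccc1` gives 0.187 h

Compound 3 holds the lowest of the three numbers. Its nearest neighbour is compound 1, and the step of a 1.3-fold lower number from compound 1 to compound 3 (0.10 log units; within the scatter) stays within the scatter. Compound 2 lies furthest off, with a 2.3-fold lower number from compound 2 to compound 3 (0.37 log units; beyond the scatter) as a modest step beyond the scatter. The remaining pair, a 1.9-fold higher number from compound 1 to compound 2 (0.27 log units; within the scatter), is again within the scatter.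

Compound 4 `NS(=O)(=O)c1cc(-c2nnc(/C=C/c3ccc(Cl)cc3)o2)c(Cl)cc1SCc1ccccc1` differs from compound 3 by 2-(4-chlorophenyl)ethenyl in place of benzamidomethyl on an aromatic carbon. All three measured steps exchange the group carried on the same ring carbon of the shared core, so they bear on this position, but none of them brings in the group that enters here. For the measured compounds named here, what they show is the spread of the series so far: exchanges at this position have moved the half-life from within the scatter up to a modest step. Going by the values given here, with no closer precedent, the step from compound 3 to compound 4 is expected to be small, a 1.3-fold higher number from compound 3 to compound 4 (0.13 log units; within the scatter), with no direction claimed beyond the scatter. For compound 4 the half-life in this assay is estimated at 0.25 h, in the range 0.11 h to 0.55 h.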

Compound 4, half-life: 0.207 h
For compound 4 the middle estimate is 1.2-fold (0.08 log units) above the measured one; the measured number falls inside the stated range.
By their numbers in this assay, from the lowest: compounds 3, 4, 1 and 2 (each within the scatter of the next, the first and the last beyond it).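

This exchange removes the saturated chain carbon that every earlier group placed on the ring carbon, and it trades the hydrogen-bond donor and acceptor of benzamidomethyl for a chlorine-bearing group. Even so, this assay gives only a 1.1-fold higher number from compound 3 to compound 4 (0.04 log units; within the scatter), and a 1.1-fold lower number from compound 1 to compound 4 (0.06 log units; within the scatter) likewise stays small, so neither the saturated chain carbon nor the amide is required for a half-life in this range among the compounds shown. For the compounds shown here, the one step to compound 4 beyond the scatter is a 2.1-fold lower number from compound 2 to compound 4 (0.32 log units; beyond the scatter), a modest gap that sets compound 2 apart from compound 4 as it does from compound 3, although compound 1 goes against a clean split by lying within the scatter of all three others; no supporting data bear on why the half-life responds in this way.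

On these data alone, it remains open whether a carboxylic acid, a primary amine or a longer chain at this position would move the half-life beyond this narrow band. Every compound shown also keeps the rest of the shared core unchanged, so the response of the half-life to exchanges elsewhere on the core remains unknown.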